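This account rests on a few compounds, and the source may have more. Where it says the series, first, only, none or still open, it means among the compounds named here.

Of the compounds shown here, three sharing one core have been tested in an ADME assay on microsomes from liver (Rattus norvegicus) for metabolic stability, read by LC-MS, using NADPH, at 37 degrees C; a lower number here means that the compound disappears faster, a higher number that the compound lasts longer: compound 1 `Cc1oc(-c2ccc(Cl)cc2)nc1CN1CCC(C(=O)NCCCN2C[C@H](C)C[C@H](C)C2)CC1`, compound 2 `Cc1oc(-c2ccc(Cl)c(Cl)c2)nc1CN1CCC(C(=O)NCCCN2C[C@H](C)C[C@H](C)C2)CC1` and compound 3 `Cc1oc(-c2c(F)cccc2F)nc1CN1CCC(C(=O)NCCCN2C[C@H](C)C[C@H](C)C2)CC1`. Compound 1 gives > 0.5 h, which is a limit of the assay and not a number. Compound 2 gives > 0.5 h, which is also a limit. Within the data shown here, compound 3 gives 0.35 h, the only actual number in the set. Any comparison here is therefore bounded by the limit of > 0.5 h in this assay, at which 2 of the 3 values shown sit.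

The next compound, compound 4 `Cc1oc(-c2c(Br)cccc2Br)nc1CN1CCC(C(=O)NCCCN2C[C@H](C)C[C@H](C)C2)CC1`, differs from compound 3 in one place: 2,6-dibromophenyl in place of 2,6-difluorophenyl on an aromatic carbon. It carries 2,6-dibromophenyl in place of 2,6-difluorophenyl on an aromatic carbon.

Two measured steps change the group at this same place: an at least 1.4-fold lower number from compound 1 to compound 3 (0.15 log units; that floor lies within the scatter), and an at least 1.4-fold lower number from compound 2 to compound 3 (0.15 log units; that floor lies within the scatter). Each gives only a floor, and both floors lie within the scatter. The remaining step, a step that the two limits leave unreadable from compound 1 to compound 2, cannot be sized. Among the measured compounds shown here, none of the measured compounds carries bromine, so the data offer no direct precedent for this swap.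

Resting on the small floor of an at least 1.4-fold lower number from compound 1 to compound 3 (0.15 log units; that floor lies within the scatter), no clear step beyond the scatter is expected in this assay. The estimated change is a 1.1-fold higher number from compound 3 to compound 4 (0.06 log units; within the scatter), which would be a slight rise at most. The expected half-life of compound 4 is 0.4 h, with an estimated range from 0.2 h to 0.7 h.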

Compound 4, half-life in the liver assay: 0.035 h
Beside the measured number, compound 4's estimate is 11-fold (1.06 log units) above it, and the stated range ends above it.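

Among these compounds, at this place on the five-membered aromatic ring, the earlier compounds offered only floors within the scatter, whereas in the liver assay the swap to 2,6-dibromophenyl gives a clear result: a 10-fold lower number from compound 3 to compound 4 (1.00 log units; beyond the scatter), although the group that leaves and the group that enters each have 8 heavy atoms. This place therefore does not accept every halogenated phenyl group equally, and compound 4 also falls well behind the two chlorinated compounds, with an at least 14-fold lower number from compound 2 to compound 4 (1.15 log units; beyond the scatter) and an at least 14-fold lower number from compound 1 to compound 4 (1.15 log units; beyond the scatter). In a physicochemical assay for solubility, in phosphate buffer, measured as kinetic solubility, at pH 7.4 (on this read-out higher numbers stand for higher solubility and lower numbers for lower solubility), compound 3 gives > 72 ug/mL, which is a limit of the assay and not a number. In the physicochemical assay compound 4 gives 62.4 ug/mL. In the physicochemical assay the same swap gives only an at least 1.1-fold lower number from compound 3 to compound 4 (0.06 log units; that floor lies within the scatter), so no clear difference can be read there, and nothing measured here explains the shorter half-life.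

The compounds shown leave open whether the loss belongs to bromine itself or to any two larger groups in these ring places, a question that 2,6-dichlorophenyl, 2,6-dimethylphenyl or 4-bromophenyl at the same place could help to separate. From the compounds shown here alone, the true half-lives of compound 1 and compound 2 also stay unknown, since both values are limits of the assay.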